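Ester alkyl trimming in the nitrophenol dihydropyridine series

The source may hold more compounds than are shown below. What is called first, only, known or untested is meant among the compounds shown, and "the series" means these compounds.

Measured so far in an assay for inhibition of Voltage-dependent L-type calcium channel subunit alpha-1C (Rattus norvegicus), read by patch clamp, tested at 10 uM; on this read-out lower numbers stand for less inhibition and higher numbers for more inhibition at the one concentration tested (going by the name of the read-out):
- compound 1 `CC1=C(C(=O)OC(C)(C)C)C(c2cc([N+](=O)[O-])ccc2O)C2=C(CCC(C)(C)C2=O)N1` gives < 30%.
- compound 2 `CCOC(=O)C1=C(C)NC2=C(C(=O)C(C)(C)CC2)C1c1cc([N+](=O)[O-])ccc1O` gives 70%.
- compound 3 `CC1=C(C(=O)OCC(C)C)C(c2cc(Br)cc([N+](=O)[O-])c2O)C2=C(CCC(C)(C)C2=O)N1` gives 10%.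

For compound 1 the value < 30% is a limit of the assay, not a number. Compound 3 stands lowest of the two numbers shown in this assay, with compound 2 nearest; compound 2 gives 70%, which sits well beyond the scatter above compound 3.

For the measured compounds named here, the one step available that changes only the ester alkyl is a number at least 40 percentage points higher from compound 1 to compound 2 (beyond the scatter). Because (the limit of < 30% in this assay, at which 1 of the 3 values shown sits), that step is known only as a lower bound, but its direction is clear: the smaller ester alkyl goes with more inhibition.

Compound 4 `CCOC(=O)C1=C(C)NC2=C(C(=O)C(C)(C)CC2)C1c1cc(Br)cc([N+](=O)[O-])c1O` has not been measured. It differs from compound 3 by methyl in place of isopropyl on a saturated chain carbon bound to an oxygen next to a carbonyl group, which reads as isobutoxycarbonyl to ethoxycarbonyl. The step from compound 1 to compound 2 bears on it directly, as the same kind of shortening at the same place, and it was large. Going by the values given here, a rise beyond the scatter is therefore expected, though the start point of compound 3 is low and the bromo substituent is shared by no measured pair.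

Compound 4 is expected to give 45%, between 20% and 70%. The step of a number 35 percentage points higher from compound 3 to compound 4 (beyond the scatter) is the estimated consequence.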

Compound 4, a percentage reported as inhibition, at one concentration (the size of the read-out at that concentration, not a potency): 50%
Beside the measured number, compound 4's estimate is 5 percentage points below it; low and high end bracket the measured number.
By their numbers in this assay, from the lowest: compound 3; then compound 4; then compound 2.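

In this assay the change from isobutoxycarbonyl to ethoxycarbonyl gives a number 40 percentage points higher from compound 3 to compound 4 (beyond the scatter) and, unlike the earlier step, it has a number at both ends, so the size of an ester alkyl change at this place is now actually measured. The earlier step, a number at least 40 percentage points higher from compound 1 to compound 2 (beyond the scatter), can be read only as a lower bound because of a limit: the limit of < 30% in this assay, at which 1 of the 4 values shown sits. For the compounds shown here, the ethyl ester now stands higher in both pairs, starting from tert-butyl on the unsubstituted nitrophenol and from isobutyl on the bromo-bearing one, and neither pair goes against this, so the direction holds with and without the bromine, though across only two pairs.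

What the bromine itself contributes stays unsettled: among the two ethyl esters, compound 2 gives 70% and compound 4 gives 50%, and one such pair cannot show whether this holds for other esters. On these data alone, it also remains open whether the trend continues to a methyl ester, or whether an amide or a carboxylic acid at this place keeps the inhibition seen with the ethyl ester.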